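A few compounds are considered here, and "the series" means these few. Any claim that something is new, unique, unknown or untested is made for them only; others in the source may bear on it.

Compound 1 `COc1ccc(C(=O)/C=C/c2cc(-c3cc(OC)c(OC)c(OC)c3)n[nH]2)cc1OC` and compound 2 `COc1cc(C(=O)/C=C/c2cc(-c3cc(OC)c(OC)c(OC)c3)n[nH]2)cc(OC)c1OC` were both tested in a functional assay on UACC-62 cells (Homo sapiens) for inhibition, read by sulforhodamine B assay, with a stated time of 48 h; on this read-out higher numbers stand for lower toxicity in this test and lower numbers for higher toxicity in this test; compound 1 gives 5980 nM and compound 2 gives 7600 nM. Going by the values given here, the step of a 1.3-fold higher number from compound 1 to compound 2 (0.10 log units; within the scatter) is the only measured step, and compound 2 stands at the higher of the two numbers, within the scatter of compound 1. Compound 3 `COc1ccc(-c2cc(/C=C/C(=O)c3cc(OC)c(OC)c(OC)c3)[nH]n2)cc1OC` differs from compound 2 by hydrogen in place of methoxy on an aromatic carbon. Among the compounds with values here, because the one measured methoxy step a 1.3-fold higher number from compound 1 to compound 2 (0.10 log units; within the scatter) stayed within the scatter, removing a methoxy elsewhere is expected to give a step of a 1.2-fold lower number from compound 2 to compound 3 (0.07 log units; within the scatter) that is no larger than the scatter. Compound 3 is therefore estimated at 6500 nM in this assay, with a range from 3000 nM to 14000 nM.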

Compound 3, concentration lethal to 50% of the cells: 8390 nM
Compound 3: the middle estimate sits 1.3-fold (0.11 log units) below what was measured, and the stated range covers the measured number.
By their numbers in this assay, from the lowest: compounds 1, 2 and 3 (each within the scatter of the next).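

In this assay, hydrogen in place of methoxy on an aromatic carbon, ortho to a methoxy group and meta to a large group, gives a 1.1-fold higher number from compound 2 to compound 3 (0.04 log units; within the scatter). The earlier compounds shown here showed a methoxy change at only one place, and this second place also shows no change beyond the scatter. Nothing available bears on why this step is so small.

The compounds shown leave open whether an amine, a carboxylic acid or a longer chain at this carbon would move the number beyond the scatter.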